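Bromo in Place of Chloro on a Second Core

This account rests on a few compounds, and the source may have more. Where it says the series, first, only, none or still open, it means among the compounds named here.

Compound 1 `COc1cc(/C=C2\CN(C)C/C(=C\c3ccc(Cl)cc3)C2=O)cc(OC)c1` is measured in an ADME assay on L02 cells (Homo sapiens) for cytotoxicity, read by MTT assay, with a stated time of 24 h (a lower number here means a stronger inhibitor, a higher number a weaker inhibitor), at 18900 nM. Compound 2 `COc1cc(/C=C2\CN(C)C/C(=C\c3ccc(Br)cc3)C2=O)cc(OC)c1` differs from compound 1 by bromo in place of chloro on an aromatic carbon. In this assay compound 2 gives 21300 nM, a step of a 1.1-fold higher number from compound 1 to compound 2 (0.05 log units; within the scatter). Compound 3 `CN1C/C(=C\c2ccc(Cl)cc2)C(=O)/C(=C/c2cccc([N+](=O)[O-])c2)C1` carries a different core; the difference between the core of compound 1 and the core of compound 3 is not broken down here. In this assay compound 3 gives only a limit, > 20000 nM. This is the limit of > 20000 nM in this assay, at which 1 of the 3 values shown sits. Compound 4 `CN1C/C(=C\c2ccc(Br)cc2)C(=O)/C(=C/c2cccc([N+](=O)[O-])c2)C1` stands to compound 3 as compound 2 stands to compound 1: the same change, (bromo in place of chloro on an aromatic carbon), at the same place. For compound 4 a step that the limit leaves unreadable from compound 3 to compound 4 is expected in this assay. That expectation rests on the step of a 1.1-fold higher number from compound 1 to compound 2 (0.05 log units; within the scatter). Compound 4 is thus estimated at 25000 nM, with a range from 14000 nM to 45000 nM, and most likely again reported only as a limit.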

Compound 4, half-maximal inhibitory concentration: 9850 nM
Beside the measured number, compound 4's estimate is 2.5-fold (0.40 log units) above it; measured number outside the range, below it.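

In this assay compound 3 is reported only as a limit, > 20000 nM. On this second core, bromo in place of chloro reads as an at least 2.0-fold lower number from compound 3 to compound 4 (0.30 log units; that floor lies within the scatter), and set beside the first core the comparison stands as follows: the same change on two cores in this assay, a 1.1-fold higher number (0.05 log units; within the scatter) from compound 1 to compound 2 and an at least 2.0-fold lower number (0.30 log units; that floor lies within the scatter) from compound 3 to compound 4; the limit leaves it open whether they differ These compounds thus show a lower number for compound 4 than the limit of compound 3, but they do not show that the change carries from one core to the other with the same size, nor that it behaves differently on the two.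

From the compounds shown here alone, the size of the step on the second core remains open, with only a limit at one end. Also open, going by these compounds, is what a fluoro or an amino group would give in the same place on either core.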